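This account rests on a few compounds, and the source may have more. Where it says the series, first, only, none or still open, it means among the compounds named here.

Among the compounds with values here, in a functional assay with Oryctolagus cuniculus as the target (a lower number here means a stronger inhibitor, a higher number a weaker inhibitor), compound 1 (`COc1ccc(-c2nc(N=C(N)N)sc2-c2ccc(OC)cc2)cc1`) gives 31000 nM, and compound 2 (`CNC(=N)Nc1nc(-c2ccc(OC)cc2)c(-c2ccc(OC)cc2)s1`) gives 62 nM, the lower of the two numbers so far. Compound 3 (`CC/N=C(/N)Nc1nc(-c2ccc(OC)cc2)c(-c2ccc(OC)cc2)s1`) keeps the shared core of compound 2 and differs from it by a group of 5 heavy atoms (3 carbon, 2 nitrogen; no ring) in place of a group of 4 heavy atoms (2 carbon, 2 nitrogen; no ring), on a nitrogen on an aromatic ring. Within the data shown here, only one measured step bears on this change: a 500-fold lower number from compound 1 to compound 2 (2.70 log units; beyond the scatter). That large step also put a larger group in place of a smaller one, but it was made at a different atom, and one step shows no trend. A repeat of its size is not expected here, and the data do not show whether further enlargement helps or harms. The change expected in this assay is a modest rise in the number, estimated as a 2.4-fold higher number from compound 2 to compound 3 (0.38 log units; beyond the scatter). For compound 3 the estimated value is 150 nM, with an expected range from 25 nM to 1200 nM.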

Compound 3, half-maximal inhibitory concentration: > 100 nM
Compound 3: only a limit was reported; the forecaster's own chance of this, stated with the estimate: 5%; the middle value does not contradict the limit.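

For compound 3, this assay gives only a limit, > 100 nM, and not a number. Set against compound 2, that limit gives an at least 1.6-fold higher number from compound 2 to compound 3 (0.20 log units; that floor lies within the scatter), so this first change on a nitrogen on an aromatic ring, a group of 5 heavy atoms in place of a group of 4, shows no loss beyond the scatter, though it does not rule one out either. The step from compound 1 to compound 3 cannot be read, and what can be said about this position ends at the limit: the limit of > 100 nM in this assay, at which 1 of the 3 values shown sits.

The compounds shown leave open how far the true number of compound 3 lies from that of compound 2, and so whether enlarging this group costs anything at all. They also leave open how a longer chain, a cyclopropyl ring or a hydroxyl-bearing chain on that nitrogen would read.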